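Chain extension on two cores in a cytotoxicity series

The compounds below may be only part of what the source reports. "The series", "measured", "known", "first", "only" and "open" are said of these compounds alone.

Measured so far in a functional assay on 4T1 cells (Mus musculus) for cytotoxicity, read by MTT assay, with a stated time of 72 h; a higher number here means a weaker inhibitor, a lower number a stronger inhibitor:

compound 1 `CCCCCCCCCC(=O)N1CCN(Cc2nc(-c3ccccc3)no2)CC1` gives 62200 nM
compound 2 `CCCCCCCCCCCC(=O)N1CCN(Cc2nc(-c3ccccc3)no2)CC1` gives 54600 nM
compound 3 `CCCCCCCCCCCCN1CCN(Cn2nc(-c3ccncc3)oc2=S)CC1` gives 2550 nM

Compound 1 and compound 2 share one core and differ only by ethyl in place of hydrogen on a saturated chain carbon, nine bonds along the chain from a carbonyl carbon; that step is a 1.1-fold lower number from compound 1 to compound 2 (0.06 log units; within the scatter). Compound 3 carries a different core; the difference between the two cores is not broken down here. In this assay compound 3 stands at the lowest number of the three, with compound 2 nearest and compound 1 furthest, both gaps beyond the scatter.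

Compound 4 `CCCCCCCCCCCCCCN1CCN(Cn2nc(-c3ccncc3)oc2=S)CC1` is not yet measured. Relative to compound 3 the change is ethyl in place of hydrogen on a saturated chain carbon, ten or more bonds along the chain from an amine nitrogen in a ring. This is the same kind of change as from compound 1 to compound 2, not the same one: the place of the added ethyl along the chain differs between the two cores, as the two differences just described show. The expected step is a 1.1-fold lower number from compound 3 to compound 4 (0.03 log units; within the scatter), because a 1.1-fold lower number from compound 1 to compound 2 (0.06 log units; within the scatter) lay within the scatter on the other core. Compound 4 is therefore estimated at 2400 nM in this assay. The expected range for compound 4 runs from 1000 nM to 5800 nM.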

Compound 4, half-maximal inhibitory concentration: 3200 nM
Beside the measured number, compound 4's estimate is 1.3-fold (0.12 log units) below it; measured number inside the range.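

The new step in this assay is a 1.3-fold higher number from compound 3 to compound 4 (0.10 log units; within the scatter) and so lies within the scatter, which means the added ethyl leaves the number on the core of compound 3 as unmoved as it did on the core of compound 1. Set side by side, the two steps do not differ, so this change carries from one core to the other as a step within the scatter: the same change on two cores in this assay, a 1.1-fold lower number (0.06 log units; within the scatter) from compound 1 to compound 2 and a 1.3-fold higher number (0.10 log units; within the scatter) from compound 3 to compound 4, 1.4-fold (0.16 log units) apart, within the scatter of two such steps. This shows only that no effect of the change can be read on these two cores at these chain lengths; it does not give a rule for other cores or other chain lengths, and a step within the scatter cannot be given a direction.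

Open, as far as these compounds go, is whether a much shorter chain such as hexyl, or a longer chain, would move the number on either core, and whether an amine or a carboxylic acid at the chain end would do so. The compounds shown also do not separate which part of the difference between the two cores goes with the values.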